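The source may report more compounds than this note shows. Statements on the series, on what has been measured and on what is new or still open speak of the compounds shown alone.

Compound 1 `CC(=O)Nc1cccc(C2CCN(CCCn3c(-c4ccccc4)nc4ccccc43)CC2)c1`: 2 nM
Compound 2 `CC(=O)Nc1cccc(C2CCN(CCCn3c(-c4ccccc4C(F)(F)F)nc4ccccc43)CC2)c1`: 50 nM
Compound 3 `CC(=O)Nc1cccc(C2CCN(CCCn3c(-c4cccc(C(F)(F)F)c4)nc4ccccc43)CC2)c1`: 30 nM

In an assay for displacement of a labelled ligand from melanin-concentrating hormone receptor 1 (Homo sapiens), read by fluorescence (on this read-out lower numbers stand for stronger inhibition and higher numbers for weaker inhibition), compound 3 stands second highest of the three numbers. Its nearest neighbour is compound 2, with a 1.7-fold lower number from compound 2 to compound 3 (0.22 log units; within the scatter), while compound 1 lies furthest away, with a 15-fold higher number from compound 1 to compound 3 (1.18 log units; beyond the scatter). Compound 4 `COc1ccccc1-c1nc2ccccc2n1CCCN1CCC(c2cccc(NC(C)=O)c2)CC1` has not yet been measured. It differs from compound 3 in one place: 2-methoxyphenyl in place of 3-(trifluoromethyl)phenyl on an aromatic carbon. Among the compounds with values here, two measured steps bear on this change, both adding a trifluoromethyl group to the phenyl ring on the shared core: a 25-fold higher number from compound 1 to compound 2 (1.40 log units; beyond the scatter) and a 15-fold higher number from compound 1 to compound 3 (1.18 log units; beyond the scatter). In both, the number rose well beyond the scatter once the bare phenyl ring of compound 1 carried a group. Compound 4 again carries a group on that ring, but a different and smaller one, so the number is expected to stay closer to compound 2 and compound 3 than to compound 1, with wide uncertainty. Compound 4 is therefore expected to give about 15 nM, within 4 nM to 60 nM, meaning an expected step of a 2.0-fold lower number from compound 3 to compound 4 (0.30 log units; within the scatter).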

Compound 4, half-maximal inhibitory concentration: 747 nM
Compound 4: middle estimate off by 50-fold (1.70 log units), on the low side; the whole stated range lies below it.
By their numbers in this assay, from the lowest: compound 1; then compounds 3 and 2 (each within the scatter of the next); then compound 4.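

At this ring, what is attached matters, not just whether something is attached. In this assay the swap of trifluoromethyl for methoxy gives a clear rise (a 15-fold higher number from compound 2 to compound 4 (1.17 log units; beyond the scatter)), and 2-methoxyphenyl, despite having fewer heavy atoms than 3-(trifluoromethyl)phenyl, gives another (a 25-fold higher number from compound 3 to compound 4 (1.40 log units; beyond the scatter)). Set against the bare phenyl ring of the shared core, methoxy costs far more than either trifluoromethyl group did (a 370-fold higher number from compound 1 to compound 4 (2.57 log units; beyond the scatter)), and no measurement shown here accounts for that gap.

The compounds shown leave open whether the high number belongs to the methoxy group itself or to where it sits on the ring. They also leave open whether a fluorine, a hydroxyl or an amine on that ring would keep the number closer to that of compound 1.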